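A Pyridine Nitrogen Enters the Aryl Ring

The source may report more compounds than this note shows. Statements on the series, on what has been measured and on what is new or still open speak of the compounds shown alone.

Three compounds share one core and differ only in the aryl group on the tetrazole. Compound 1 `Cc1cc(NC(=O)Cn2nnc(-c3cccc(Cl)c3)n2)n(C2CCCCC2)n1` gives 300 nM in an assay on HEK293 cells for activation of Kir3.1/Kir3.2 (Homo sapiens), read by thallium flux; on this read-out higher numbers stand for an effect only at larger amounts of compound and lower numbers for an effect already at smaller amounts. Compound 2 `Cc1cc(NC(=O)Cn2nnc(-c3cc(Cl)cc(Cl)c3)n2)n(C2CCCCC2)n1` gives 980 nM in this assay, and compound 3 `Cc1cc(NC(=O)Cn2nnc(-c3cccc(F)c3)n2)n(C2CCCCC2)n1` gives 81 nM. Compound 3 thus has the lowest number of the three; the next one up is compound 1, and compound 2 lies furthest away. The measured steps are all in the halogen pattern of the aryl ring: a 3.3-fold higher number from compound 1 to compound 2 (0.51 log units; beyond the scatter), a 3.7-fold lower number from compound 1 to compound 3 (0.57 log units; beyond the scatter), and a 12-fold lower number from compound 2 to compound 3 (1.08 log units; beyond the scatter).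

Compound 4 `Cc1cc(NC(=O)Cn2nnc(-c3ccnc(F)c3)n2)n(C2CCCCC2)n1` takes the change (2-fluoropyridin-4-yl in place of 3-fluorophenyl on an aromatic carbon). Among the compounds with values here, no measured step swaps a ring carbon for a ring nitrogen, so none bears on it directly; the halogen steps show that this part of the molecule moves the number only modestly, and the new fluorine is retained. The step from compound 3 to compound 4 in this assay is therefore expected to be small, leaning toward a somewhat higher number, a 1.6-fold higher number from compound 3 to compound 4 (0.21 log units; within the scatter). Compound 4 is estimated at 130 nM, with a range from 40 nM to 450 nM.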

Compound 4, half-maximal effective concentration: 441 nM
The estimate for compound 4 lay 3.4-fold (0.53 log units) below the measured number; the range from low to high includes it.
By their numbers in this assay, from the lowest: compound 3; then compounds 1 and 4 (each within the scatter of the next); then compound 2.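

In this assay, within the data shown here, the 2-fluoropyridin-4-yl group brings a ring nitrogen to this position, a change none of the earlier compounds showed, and with the fluorine retained the number still shifts clearly: there is a 5.4-fold higher number from compound 3 to compound 4 (0.74 log units; beyond the scatter), so the advantage of the 3-fluorophenyl group does not carry over to the pyridine ring. Against the chlorine-bearing aryl groups the result looks different, with a 2.2-fold lower number from compound 2 to compound 4 (0.35 log units; beyond the scatter) and a 1.5-fold higher number from compound 1 to compound 4 (0.17 log units; within the scatter), so the new group cannot be told apart from the 3-chlorophenyl group in this assay, although it still keeps a real margin over the 3,5-dichlorophenyl group. Nothing available on these compounds accounts for the step from the phenyl ring to the pyridine ring.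

As far as these compounds go, how a 2-chloropyridin-4-yl group, a pyridin-3-yl group or a pyrimidine ring would compare at this position remains open. From the compounds shown here alone, it is also open whether a nitrile or a methoxy group in place of the fluorine on the pyridine ring would bring the number back toward that of compound 3 at 81 nM.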